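Metabolic stability across three sulfonyl-substituted acylsulfonamide analogues

The source may hold more compounds than are shown below. What is called first, only, known or untested is meant among the compounds shown, and "the series" means these compounds.

Compound 1: `CCS(=O)(=O)NC(=O)c1ccc(Nc2nc(NC3(c4ccc(Cl)cc4)CC3)nc(OCC(F)(F)F)n2)cc1` — 85%
Compound 2: `O=C(NS(=O)(=O)C1CC1)c1ccc(Nc2nc(NC3(c4ccc(Cl)cc4)CC3)nc(OCC(F)(F)F)n2)cc1` — 85%
Compound 3: `CNC(=O)NCCS(=O)(=O)NC(=O)c1ccc(Nc2nc(NC3(c4ccc(Cl)cc4)CC3)nc(OCC(F)(F)F)n2)cc1` — to be measured

Compound 1 and compound 2 share a common core and differ only at the sulfonyl sulfur. In an ADME assay on microsomes from liver (Rattus norvegicus) for metabolic stability, with a stated time of 10 min (on this read-out lower numbers stand for a less stable compound and higher numbers for a more stable compound), compound 1 gives 85%. In this assay compound 2 gives 85%. Among the measured compounds shown here, the single measured step, no change at the digits printed from compound 1 to compound 2 (within the scatter), shows that exchanging one small carbon group for another at this position left the read-out unmoved. Compound 2 therefore stands level with compound 1 on the numbers available, with no other reference point.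

Compound 3 is built on the same core with the following change: 2-((methylcarbamoyl)amino)ethyl in place of cyclopropyl on a sulfonyl sulfur. For the measured compounds named here, only the step from compound 1 to compound 2 bears on this position, and it was flat. Going by the values given here, that step concerned a far smaller exchange than the one made here, so it offers limited guidance, and no measured compound carries a chain of this kind. On the evidence of no change at the digits printed from compound 1 to compound 2 (within the scatter), compound 3 is expected to sit close to compound 2 in this assay, with the step of a number 3 percentage points lower from compound 2 to compound 3 (within the scatter) estimated as small. Compound 3 is estimated at 82%, within a range of 65% to 95%.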

Compound 3, percent of the compound remaining: 100%
Compound 3: the middle estimate sits 18 percentage points below what was measured, and the stated range ends below it.
By their numbers in this assay, from the lowest: compounds 1 and 2 (each within the scatter of the next); then compound 3.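

The sulfonyl sulfur position proved responsive to the group it carries, which the earlier pair of small carbon groups could not show: in this assay the exchange of cyclopropyl for 2-((methylcarbamoyl)amino)ethyl gives a number 15 percentage points higher from compound 2 to compound 3 (beyond the scatter) and so moves compound 3 toward the more stable end of the read-out. Read against the ethyl group, the same result appears as an addition to the chain, with (methylcarbamoyl)amino in place of hydrogen on a saturated chain carbon, two bonds along the chain from a sulfonyl sulfur, giving a number 15 percentage points higher from compound 1 to compound 3 (beyond the scatter) and showing that this larger, ring-free chain with its hydrogen-bond donors costs nothing here and in fact comes with a modest gain. The data offer no explanation for this gain.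

With a single compound of this kind, the three compounds cannot separate the contribution of the terminal methylcarbamoyl unit from that of the added nitrogen on the ethyl chain. Going by these compounds, it remains open whether a plain amine or a carboxylic acid at the end of the ethyl chain, or a longer chain ending in the same (methylcarbamoyl)amino group, would hold the same level in this assay or lose it.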